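This account rests on a few compounds, and the source may have more. Where it says the series, first, only, none or still open, it means among the compounds named here.

In an ADME assay on microsomes from liver (Rattus norvegicus) for metabolic stability (a higher number here means that the compound lasts longer, a lower number that the compound disappears faster), compound 2 `Nc1nc(NCCNc2ncc(-c3ncc[nH]3)c(-c3ccccc3Cl)n2)ccc1[N+](=O)[O-]` gives > 0.5 h, which is a limit of the assay rather than a number. Compound 1 `FC(F)(F)c1ccc(NCCNc2ncc(-c3ncc[nH]3)c(-c3ccc(Cl)cc3Cl)n2)nc1` also returns only a limit, > 0.5 h. Both values thus sit at the limit of > 0.5 h in this assay, at which 2 of the 2 values shown sit, so compound 2 stands at the boundary of what this assay reports, and nothing in these two results separates it from compound 1 by any measured amount. Compound 3 `Nc1nc(NCCNc2ncc(-c3ncc[nH]3)c(-c3ccc(F)cc3Cl)n2)ccc1[N+](=O)[O-]` differs from compound 2 by fluoro in place of hydrogen on an aromatic carbon. Among the compounds with values here, no pair of measured compounds shows what such a change does in this assay, so the expectation rests on compound 2 alone. The expected step is a step that the limit leaves unreadable from compound 2 to compound 3, none beyond the usual scatter, with a good chance that this assay again reports only its limit. Compound 3 is therefore estimated at 0.8 h, with a range from 0.4 h to 1.6 h.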

Compound 3, half-life: > 0.5 h
Compound 3: a limit, no number; the forecaster's own chance of this, stated with the estimate: 70%; the middle value is on the limit's open side.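

Compound 3 also gives only a limit, > 0.5 h, so no step between compound 2 and compound 3 can be read: the limit of > 0.5 h in this assay, at which 3 of the 3 values shown sit.

The compounds shown leave open how long each actually lasts in this assay, and whether fluoro in place of hydrogen changes that at all.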